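The compounds below may be only part of what the source reports. "The series", "measured", "known", "first", "only" and "open" are said of these compounds alone.

Compound 1 `O=C(/C=C/c1ccc(Oc2ncnc3ccc(Cl)cc23)cc1)/C=C/c1ccc(Cl)c(Cl)c1` gives 16900 nM in a functional assay on MGC-803 cells (Homo sapiens) for inhibition, read by MTT assay, with a stated time of 72 h; a lower number here means a stronger inhibitor, a higher number a weaker inhibitor. Compound 2 `O=C(/C=C/c1ccc(Cl)c(Cl)c1)/C=C/c1ccccc1Oc1ncnc2ccc(Cl)cc12` gives 16200 nM.

Compound 1 has the highest of the two numbers, and compound 2 lies within the scatter of it, so the two show no difference. Compound 3 `O=C(/C=C/c1ccc(Oc2ncnc3ccc(Cl)cc23)cc1)/C=C/c1cc([N+](=O)[O-])ccc1Cl` has not yet been measured. It differs from compound 1 in one place: 2-chloro-5-nitrophenyl in place of 3,4-dichlorophenyl on a double-bonded chain carbon bound to a double-bonded chain carbon. Among the measured compounds shown here, no measured pair shows what such a change does, so the step is expected to be small, in either direction or none beyond the scatter. Compound 3 is expected to give 15000 nM, between 6000 nM and 40000 nM, which means an estimated 1.1-fold lower number from compound 1 to compound 3 (0.05 log units; within the scatter).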

Compound 3, half-maximal inhibitory concentration: 2150 nM
Estimate against measurement, compound 3: 7.0-fold (0.84 log units) above; the measured number lies below the stated range.
By their numbers in this assay, from the lowest: compound 3; then compounds 2 and 1 (each within the scatter of the next).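

In this assay, the aryl group on a double-bonded chain carbon bound to a double-bonded chain carbon proves able to change the result: 2-chloro-5-nitrophenyl in place of 3,4-dichlorophenyl gives a 7.9-fold lower number from compound 1 to compound 3 (0.90 log units; beyond the scatter), a modest gain. The two rings differ in more than one feature, so this single step cannot show which feature matters. Nothing measured here explains the step.

From the compounds shown here alone, whether the nitro group itself matters remains open, as does whether a ring carrying an amine or a carboxylic acid in its place would behave the same way. Going by these compounds, the effect of this change on compound 2 also remains open.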